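A few compounds are considered here, and "the series" means these few. Any claim that something is new, unique, unknown or untested is made for them only; others in the source may bear on it.

Compound 1, `O=S(=O)(c1ccccc1)c1nc2ccccc2nc1Nc1ccc(Cl)cc1`, gives 15300 nM in a functional assay on PC-3 cells (Homo sapiens) for cytotoxicity, read by MTT assay, with a stated time of 72 h; on this read-out lower numbers stand for stronger inhibition and higher numbers for weaker inhibition. Compound 2, `COc1ccc(S(=O)(=O)c2nc3ccccc3nc2Nc2ccc(Cl)cc2)cc1`, differs from it by methoxy in place of hydrogen on an aromatic carbon and gives 31800 nM in this assay, a step of a 2.1-fold higher number from compound 1 to compound 2 (0.32 log units; beyond the scatter). Compound 3, `COc1cc(Nc2nc3ccccc3nc2S(=O)(=O)c2ccc(F)cc2)cc(OC)c1`, gives 4530 nM in this assay; the difference between its core and the core of compound 1 is not broken down here. Compound 4, `COc1cc(Nc2nc3ccccc3nc2S(=O)(=O)c2ccc(F)cc2)cc(OC)c1OC`, differs from compound 3 by methoxy in place of hydrogen on an aromatic carbon. This is the same kind of change as that seen from compound 1 to compound 2, but here the place is ortho to two methoxy groups as well as para to a large group. Because the earlier step was a 2.1-fold higher number from compound 1 to compound 2 (0.32 log units; beyond the scatter), compound 4 is expected to show a step of a 1.9-fold higher number from compound 3 to compound 4 (0.27 log units; within the scatter). Compound 4 is therefore estimated at 8500 nM, within a range from 3500 nM to 20000 nM.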

Compound 4, half-maximal inhibitory concentration: > 50000 nM
Compound 4 ended at the assay's limit; the forecaster's own chance of this, stated with the estimate: 5%; at least 5.8-fold (0.76 log units) between middle value and limit.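

Carried to the core of compound 3, methoxy in place of hydrogen on an aromatic carbon gave an at least 11-fold higher number from compound 3 to compound 4 (1.04 log units; beyond the scatter) in this assay. Compound 4 gives > 50000 nM, which is a limit of the assay and not a number. The two steps point the same way but differ in size, so the step on one core did not carry over in size to the other, while two pairs cannot show how large the true gap is or what sets it: the same change on two cores in this assay, a 2.1-fold higher number (0.32 log units; beyond the scatter) from compound 1 to compound 2 and an at least 11-fold higher number (1.04 log units; beyond the scatter) from compound 3 to compound 4, at least 5.3-fold (0.72 log units) apart, beyond the scatter of two such steps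

The compounds shown leave open whether ethoxy or a chlorine atom at that same place on compound 3 would give a step like that of methoxy. They also leave open how an amine or a carboxylic acid there would read out.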